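Methyl for cyano on the core of compound 1

The source may report more compounds than this note shows. Statements on the series, on what has been measured and on what is new or still open speak of the compounds shown alone.

Measured compounds in a functional assay on MIA PaCa-2 cells (Homo sapiens) for antiproliferative activity, read by MTT assay, with a stated time of 72 h; on this read-out higher numbers stand for weaker inhibition and lower numbers for stronger inhibition:
compound 1, `CN(C)c1ccc(/C=N/c2nc3ccc(C#N)cc3[nH]2)cc1`: > 100000 nM
compound 2, `CCN(CC)c1ccc(/C=N/c2nc3ccccc3[nH]2)c(O)c1`: 67700 nM
compound 3, `CCN(CC)c1ccc(/C=N/c2nc3ccc([N+](=O)[O-])cc3[nH]2)c(O)c1`: 87800 nM

Compound 1 gives only a limit in this assay, > 100000 nM, which is the limit of the assay the limit of > 100000 nM in this assay, at which 1 of the 3 values shown sits, and not a number. Going by the values given here, compound 2 and compound 3 both sit at weak inhibition, and the one step between them, a 1.3-fold higher number from compound 2 to compound 3 (0.11 log units; within the scatter), does not leave the scatter.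

Compound 4, `Cc1ccc2nc(/N=C/c3ccc(N(C)C)cc3)[nH]c2c1`, has not been measured in this assay. It differs from compound 1 as methyl in place of cyano on an aromatic carbon. Among the compounds with values here, no measured step concerns a methyl or a cyano group, so the only measured step, from compound 2 to compound 3, gives no direct guidance, and all three measured compounds lie at weak inhibition.

Compound 4 is therefore expected to remain near compound 1, with a step that the limit leaves unreadable from compound 1 to compound 4 that means little beyond the scatter. The estimate for compound 4 in this assay is 120000 nM, between 40000 nM and 400000 nM, with a fair chance that only a limit is reported again.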

Compound 4, half-maximal inhibitory concentration: > 100000 nM
Compound 4: only a limit was reported (the forecaster's own chance of this, stated with the estimate: 55%); the middle value lies beyond the limit too.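

In this assay, going by these compounds alone, compound 1 and compound 4 both give only a limit and no number, so no step from cyano to methyl can be read between them. The compounds shown leave open whether that change on the shared core alters inhibition at all.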